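This account rests on a few compounds, and the source may have more. Where it says the series, first, only, none or still open, it means among the compounds named here.

Going by the values given here, compound 1 `Cc1nc(-c2cccc(CN(C)c3ccc4[nH]nc(C(=O)O)c4c3)c2)sc1C` is one of three compounds measured in an assay on isolated protein for inhibition of 2-Hydroxyacid oxidase 1 (Homo sapiens), with stated times of 30 min and 15 min; a higher number here means a weaker inhibitor, a lower number a stronger inhibitor. Compound 1 gives 290 nM, the highest of the three numbers. Among the compounds with values here, compound 2 `CC(C)c1csc(-c2cccc(CNc3ccc4[nH]nc(C(=O)O)c4c3)c2O)n1` gives 65 nM and compound 3 `CC(C)c1noc(-c2cccc(CNc3ccc4[nH]nc(C(=O)O)c4c3)c2O)n1` gives 47 nM; the one single-point step among them, a 1.4-fold lower number from compound 2 to compound 3 (0.14 log units; within the scatter), stays within the scatter. Compound 4 `CC(C)c1csc(-c2cccc(CN(C)c3ccc4[nH]nc(C(=O)O)c4c3)c2)n1` differs from compound 1 by 4-isopropyl-1,3-thiazol-2-yl in place of 4,5-dimethyl-1,3-thiazol-2-yl on an aromatic carbon. Within the data shown here, no measured step isolates this swap: compound 2 also carries the 4-isopropyl-1,3-thiazol-2-yl group yet differs from compound 1 in two further places, so its lower number cannot be laid to the thiazole substituent alone. A step of modest size, not clearly beyond the scatter, is therefore expected, a 1.5-fold lower number from compound 1 to compound 4 (0.16 log units; within the scatter). Compound 4 is estimated at 200 nM, between 80 nM and 500 nM.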

Compound 4, half-maximal inhibitory concentration: 710 nM
Estimate against measurement, compound 4: 3.6-fold (0.55 log units) below; measured number outside the range, above it.
By their numbers in this assay, from the lowest: compounds 3 and 2 (each within the scatter of the next); then compound 1; then compound 4.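

In this assay, the step of a 2.4-fold higher number from compound 1 to compound 4 (0.39 log units; beyond the scatter) shows that this position, on an aromatic carbon of a six-membered aromatic ring of carbon only, responds to the substitution on the thiazole even though the ring itself stays the same. Exchanging 4,5-dimethyl-1,3-thiazol-2-yl for 4-isopropyl-1,3-thiazol-2-yl is therefore not a neutral change in the setting of compound 1. Nothing available explains this step. From the compounds shown here alone, it remains open whether the same swap runs the same way with the hydroxyl group of compound 2 present, and whether a cyclopropyl or tert-butyl group on the thiazole would follow the isopropyl.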